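Fluoro for Ethyl on the Core of Compound 3

This account rests on a few compounds, and the source may have more. Where it says the series, first, only, none or still open, it means among the compounds named here.

Of the compounds shown here, three share a core and have been measured in a functional assay on A-375 cells (Homo sapiens) for antiproliferative activity, read by MTT assay, with a stated time of 24 h, tested at 11.11 ug/mL; on this read-out lower numbers stand for a weaker effect and higher numbers for a stronger effect at the one concentration tested. Compound 1, `Cc1c(C(=O)Nc2c(F)cc(-c3cccc(F)c3)cc2F)nc2ccc(F)cc2c1O`, gives 16.2%. Compound 2, `Cc1ccc2nc(C(=O)Nc3c(F)cc(-c4cccc(F)c4)cc3F)c(C)c(C(=O)O)c2c1`, gives 19.2%. Compound 3, `CCc1ccc2nc(C(=O)Nc3c(F)cc(-c4cccc(F)c4)cc3F)c(C)c(C(=O)O)c2c1`, gives 38.9%, the highest of the three numbers, with its steps to compound 2 and to compound 1 both beyond the scatter. For the measured compounds named here, the one step in which a single place changes is a number 19.7 percentage points higher from compound 2 to compound 3 (beyond the scatter).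

Compound 4 is `Cc1c(C(=O)Nc2c(F)cc(-c3cccc(F)c3)cc2F)nc2ccc(F)cc2c1C(=O)O`. It differs from compound 3 by fluoro in place of ethyl on an aromatic carbon. Going by the values given here, no measured step bears directly on a fluoro entering at this place; the nearest guide is the step from compound 2 to compound 3, where ethyl in place of methyl at that very carbon raised the read-out by a modest amount beyond the scatter. Compound 1 carries the same fluoro at that place and sits low, though it differs from compound 4 elsewhere, so its value can only be noted, not used as a step. On the strength of a number 19.7 percentage points higher from compound 2 to compound 3 (beyond the scatter) a step downward in this assay is expected for the change to compound 4, roughly reversing that gain, so that a number 20.9 percentage points lower from compound 3 to compound 4 (beyond the scatter) is expected. Compound 4 is therefore estimated at 18%, with a range from 8% to 30%.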

Compound 4, a percentage reported as inhibition, at one concentration (the size of the read-out at that concentration, not a potency): 36.3%
Compound 4: the middle estimate sits 18.3 percentage points below what was measured; measured number above the stated range.
By their numbers in this assay, from the lowest: compounds 1 and 2 (each within the scatter of the next); then compounds 4 and 3 (each within the scatter of the next).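

In this assay, fluoro in place of ethyl on the aromatic carbon gives a number 2.6 percentage points lower from compound 3 to compound 4 (within the scatter), so the two groups cannot be told apart at this place. Fluoro in place of methyl on the same carbon gives a number 17.1 percentage points higher from compound 2 to compound 4 (beyond the scatter), which shows that the gain seen with ethyl does not depend on a carbon chain: of the three groups shown here, only methyl goes with the lower number, and fluoro, a single fluorine, reads level with the two-carbon ethyl. With fluoro held at this place, carboxy in place of hydroxy on an aromatic carbon gives a number 20.1 percentage points higher from compound 1 to compound 4 (beyond the scatter), so the low number of compound 1 goes with the hydroxy and not with the fluoro.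

Still open, as far as these compounds go, is whether an amine, a methoxy group or a longer chain such as propyl on this carbon would read level with ethyl and fluoro or fall back towards methyl, and a reading at one concentration gives no potency for any of them. The data shown offer no explanation for why methyl differs from ethyl and fluoro at this place.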